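Aryloxyacetamide series: cytotoxicity in HepG2 cells

The compounds below may be only part of what the source reports. "The series", "measured", "known", "first", "only" and "open" are said of these compounds alone.

Measured so far:
compound 1, `CCC(Oc1cc(C)nc2ccc(OC)cc12)C(=O)Nc1cc(C)cc(C)c1`, 79400 nM in a toxicity assay on HepG2 cells (Homo sapiens) for inhibition, read by CellTiter-Glo, with a stated time of 48 h; on this read-out lower numbers stand for stronger inhibition and higher numbers for weaker inhibition
compound 2, `COc1ccc2nc(C)cc(OCC(=O)Nc3cc(C)ccc3C)c2c1`, > 100000 nM
compound 3, `COc1ccc2nc(C)cc(OCC(=O)Nc3cc(OC)c(Cl)cc3OC)c2c1`, > 100000 nM

Compound 2 is the starting point of the step followed here. In this assay compound 2 gives only a limit of the assay, > 100000 nM, and not a number. Compound 3 likewise returns only a limit, > 100000 nM. Within the data shown here, compound 1 is the one compound of the three with a number, 79400 nM. The weight of the data lies at the limit of > 100000 nM in this assay, at which 2 of the 3 values shown sit. Among the measured compounds shown here, no step between measured compounds that differ in a single place is available, so no measured size of change can be drawn from this set.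

Compound 4, `COc1ccc2nc(C)cc(OCC(=O)Nc3nc(C)c(C)s3)c2c1`, is not yet measured. It differs from compound 2 in one place: 4,5-dimethyl-1,3-thiazol-2-yl in place of 2,5-dimethylphenyl on an amide-type nitrogen.

With compound 2 standing at a limit and compound 1 only modestly inside the measurable range, the expectation for compound 4 in this assay is no change beyond the scatter; the step of a number no higher from compound 2 to compound 4 (the limit leaves the size open) is expected to be small and may well end again at the limit. Compound 4 is therefore estimated at 100000 nM, with a range from 40000 nM to 250000 nM.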

Compound 4, half-maximal inhibitory concentration: > 100000 nM
Compound 4 was reported as a limit; the forecaster's own chance of this, stated with the estimate: 65%; the middle value sits exactly at the limit.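

In this assay compound 4 gives > 100000 nM, a limit of the assay. Compound 2 gives > 100000 nM, also a limit. The change from compound 2 to compound 4 therefore cannot be read as a step of any size. The compounds shown leave open whether 4,5-dimethyl-1,3-thiazol-2-yl in place of 2,5-dimethylphenyl changes the read-out at all.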